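This account rests on a few compounds, and the source may have more. Where it says the series, first, only, none or still open, it means among the compounds named here.

Of the compounds shown here, three have so far been measured in an ADME assay on MCF-10A cells (Homo sapiens) for cytotoxicity, read by sulforhodamine B assay, with a stated time of 48 h; a lower number here means a stronger inhibitor of growth, a higher number a weaker inhibitor of growth. Compound 1 `CCN(CC)CN1C(=O)/C(=N\c2nc3ccc(C)cc3s2)c2ccccc21` gives 20400 nM in this assay. Compound 2 `Cc1ccc2nc(/N=C3\C(=O)N(CN4CCCCC4)c4ccccc43)sc2c1` shares the core of compound 1; in this assay compound 2 gives 38900 nM. Compound 3 `O=C1C(=O)N(CN2CCCCC2)c2cccc(Br)c21` is built on a different core, and the difference between the two cores is not broken down here. In this assay compound 3 gives 66900 nM, the highest of the three numbers; it lies within the scatter of the number for compound 2 and beyond the scatter of the number for compound 1.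

Among the measured compounds the one counted step is diethylamino in place of piperidin-1-yl on a saturated chain carbon bound to an amide-type nitrogen in a ring, and it made a 1.9-fold lower number from compound 2 to compound 1 (0.28 log units; within the scatter). Compound 4 `CCN(CC)CN1C(=O)C(=O)c2c(Br)cccc21` has not yet been measured. It stands to compound 3 as compound 1 stands to compound 2, through (diethylamino in place of piperidin-1-yl on a saturated chain carbon bound to an amide-type nitrogen in a ring), the same change carried over onto the core of compound 3. The expectation for compound 4 therefore rests on a single earlier instance of this change, and that instance lay within the scatter, so a small step downward or none at all is the natural guess. Compound 4 is expected to give about 45000 nM in this assay, with a likely range from 20000 nM to 100000 nM. For compound 4 that estimate means a step of a 1.5-fold lower number from compound 3 to compound 4 (0.17 log units; within the scatter), close to the earlier one in size.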

Compound 4, concentration for 50% growth inhibition: 113000 nM
Estimate against measurement, compound 4: 2.5-fold (0.40 log units) below; measured number outside the range, above it.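

In this assay, diethylamino in place of piperidin-1-yl on the core of compound 3 gives a 1.7-fold higher number from compound 3 to compound 4 (0.23 log units; within the scatter), so the step seen earlier on the core of compound 1 was not a reliable guide to this one. Set side by side, the two steps do not match: the same change on two cores in this assay, a 1.9-fold lower number (0.28 log units; within the scatter) from compound 2 to compound 1 and a 1.7-fold higher number (0.23 log units; within the scatter) from compound 3 to compound 4, 3.2-fold (0.51 log units) apart, beyond the scatter of two such steps. This shows that, in this series, the size and direction of this change cannot simply be carried from one core to the other, but it does not establish a true reversal, as each step taken alone lies within the scatter and only the gap between them lies beyond it; two pairs also cannot show which feature of the cores separates the steps.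

Only diethylamino and piperidin-1-yl appear on the saturated chain carbon, which leaves open whether another amine, such as morpholine or dimethylamino, would give matching or differing steps on these two cores. From the compounds shown here alone, it also remains open whether the gap between the steps would hold up on repeated measurement or recur on a further core.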